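The source may hold more compounds than are shown below. What is called first, only, known or untested is meant among the compounds shown, and "the series" means these compounds.

Measured in a functional assay on MDA-MB-231 cells (Homo sapiens) for inhibition, read by MTT assay, with a stated time of 48 h; a lower number here means a stronger inhibitor of growth, a higher number a weaker inhibitor of growth:
compound 1 `NS(=O)(=O)c1ccc(Nc2ncnc3ccc(NC(=S)NCc4ccccc4)cc23)cc1`: > 30000 nM, a limit
compound 2 `N=C(N)NS(=O)(=O)c1ccc(Nc2ncnc3ccc(NC(=S)NCc4ccccc4)cc23)cc1`: > 30000 nM, a limit
compound 3 `FC(F)(F)c1cc(NC(=S)Nc2ccc3ncnc(Nc4cccc(Br)c4)c3c2)ccc1Cl`: 1100 nM

For the measured compounds named here, compound 3 is the only compound with a readable number, and the others stand at the limit of > 30000 nM in this assay, at which 2 of the 3 values shown sit. Compound 4 `S=C(NCc1ccc(Cl)cc1)Nc1ccc2ncnc(Nc3cccc(Br)c3)c2c1` swaps one group: 4-chlorobenzyl in place of 4-chloro-3-(trifluoromethyl)phenyl on an amide-type nitrogen. Going by the values given here, the only measured step, a step that the two limits leave unreadable from compound 1 to compound 2, cannot be sized and concerns a sulfonamide nitrogen, so it does not bear on this swap. The one weak hint is that compound 1, which also has a benzyl group on that nitrogen but differs elsewhere too, gives > 30000 nM, a limit. A weakening is therefore expected, estimated as a 3.6-fold higher number from compound 3 to compound 4 (0.56 log units; beyond the scatter). Compound 4 is estimated at 4000 nM, with an expected range of 1200 nM to 15000 nM.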

Compound 4, concentration for 50% growth inhibition: 23000 nM
Compound 4: middle estimate off by 5.8-fold (0.76 log units), on the low side; measured number outside the range, above it.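

In this assay, the group on the amide-type nitrogen clearly matters: 4-chlorobenzyl in place of 4-chloro-3-(trifluoromethyl)phenyl gives a 21-fold higher number from compound 3 to compound 4 (1.32 log units; beyond the scatter). For the compounds shown here, this is the first step here that can be read, as the earlier one cannot. Compound 4 now reads close to the limit of the assay: the limit of > 30000 nM in this assay, at which 2 of the 4 values shown sit.

The swap both removes the trifluoromethyl group and replaces a phenyl with a benzyl, so the compounds shown cannot separate these two changes. A plain 4-chlorophenyl group would help to separate them, while a longer chain on that nitrogen remains an open case.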